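The compounds below may be only part of what the source reports. "The series", "measured", "known", "first", "only" and "open" are said of these compounds alone.

Measured compounds:
compound 1 `C=CC(=O)Nc1cccc(Nc2nc(N)nc(Nc3ccc(Oc4ccccc4)cc3)n2)c1`: 8320 nM
compound 2 `C=CC(=O)Nc1cccc(Nc2ncnc(Nc3ccc(C(=O)Nc4ccc(C)cn4)cc3)n2)c1`: 125000 nM
compound 3 `C=CC(=O)N1CCc2ccc(Nc3ncnc(Nc4ccc(C(=O)N5CCCCC5)cc4)n3)cc21`: 2840 nM

In a functional assay on Raji cells (Homo sapiens) for antiproliferative activity, read by CCK-8 assay, with a stated time of 24 h (a higher number here means a weaker inhibitor, a lower number a stronger inhibitor), compound 2 stands highest of the three numbers. Compound 1 sits a good way lower, and compound 3 lower still; both gaps from compound 2 are beyond the usual scatter. No two of the measured compounds differ in a single place, so the size of any one change is not known from these three, and the other two compounds differ from compound 2 at more than one point of the shared core.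

Compound 4 `C=CC(=O)Nc1cccc(Nc2ncnc(Nc3ccc(-c4cccnc4)cc3)n2)c1` has not yet been measured in this assay. It is reached from compound 2 by one change:

pyridin-3-yl in place of (5-methylpyridin-2-yl)carbamoyl on an aromatic carbon

The group that leaves is the largest of the three groups on this ring among the measured compounds, and the two compounds carrying a smaller group there gave lower numbers, though neither comparison is clean. A step from compound 2 downward, of moderate size, is therefore expected, a 6.3-fold lower number from compound 2 to compound 4 (0.80 log units; beyond the scatter), with a wide uncertainty. Compound 4 is estimated at 20000 nM, in the range 4000 nM to 100000 nM.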

Compound 4, half-maximal inhibitory concentration: 12400 nM
For compound 4 the middle estimate is 1.6-fold (0.21 log units) above the measured one, and the stated range covers the measured number.
By their numbers in this assay, from the lowest: compound 3; then compounds 1 and 4 (each within the scatter of the next); then compound 2.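

In this assay, among the compounds shown here, pyridin-3-yl in place of (5-methylpyridin-2-yl)carbamoyl on an aromatic carbon para to a large group gives a 10-fold lower number from compound 2 to compound 4 (1.00 log units; beyond the scatter), the only single-place reading at this position so far. The position therefore responds to this exchange, and the smaller pyridin-3-yl goes with the lower number. The change removes the carbonyl, the amide hydrogen and the methyl at once, so the step does not separate their contributions, and no measurement here accounts for it.

Open, going by these compounds, is how a plain phenyl ring, a morpholine or a carboxylic acid at this position would compare with pyridin-3-yl. Also open, on these data alone, is whether the same exchange would give a step of similar size on the cores of compound 1 and compound 3.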